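A few compounds are considered here, and "the series" means these few. Any claim that something is new, unique, unknown or untested is made for them only; others in the source may bear on it.

Measured so far:
compound 1 `CCCCCCCCc1ccc(OCC(=O)Cn2cnnn2)cc1` — 22%
compound 2 `CCCCCCCCc1ccc(OCC(=O)Cn2nnc(-c3cccc(Cl)c3)n2)cc1` — 69%

Two compounds have been run in an ADME assay on S9 fraction from liver (Rattus norvegicus) for metabolic stability, read by LC-MS, using NADPH, with a stated time of 30 min; on this read-out lower numbers stand for a less stable compound and higher numbers for a more stable compound. Compound 1 gives 22%, and compound 2 gives 69%. On these two numbers compound 1 stands lowest; its nearest neighbour is compound 2, which lies higher by a margin well beyond the scatter of repeated runs. Among the compounds with values here, compound 2 differs from compound 1 in more than one place, so no single step between them can be named; what is known is only that the two values sit far apart.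

Compound 3 `CCCCCCCCc1ccc(OCC(=O)Cn2nnnc2C)cc1` has not yet been measured in this assay. It differs from compound 1 in one place: methyl in place of hydrogen on an aromatic carbon. Within the data shown here, no measured step of this kind exists in the set, so the size of the change cannot be read from a neighbour. Given that compound 1 gives 22%, the expected step from it is modest and upward, a number 13 percentage points higher from compound 1 to compound 3 (beyond the scatter), though a result within the scatter would not surprise. Compound 3 is therefore estimated at 35%, with a range from 15% to 60%.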

Compound 3, percent of the compound remaining: 32%
For compound 3 the middle estimate is 3 percentage points above the measured one; low and high end bracket the measured number.
By their numbers in this assay, from the lowest: compounds 1 and 3 (each within the scatter of the next); then compound 2.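

In this assay, within the data shown here, methyl in place of hydrogen on the aromatic carbon between two ring nitrogen atoms gives a number 10 percentage points higher from compound 1 to compound 3 (within the scatter) and so provides the first step in this set that can be read at a single place. At this position, next to the ring atom that bears a large group, the change from 1H-tetrazol-1-yl to 5-methyl-1H-tetrazol-1-yl adds one carbon, with no ring and no net charge, and the read-out stays within the usual scatter of repeated runs. Nothing available on these compounds speaks to what lies behind this step.

As far as these compounds go, this one step shows only how methyl behaves at this carbon on the core of compound 1, so it remains open whether a longer chain such as ethyl or propyl, an amine or a carboxylic acid at the same carbon would move the read-out beyond the scatter. From the compounds shown here alone, it also remains open whether methyl would give a similar step on a different core, since a single pair of compounds supports no wider pattern.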